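The source may report more compounds than this note shows. Statements on the series, on what has been measured and on what is new or still open speak of the compounds shown alone.

Compound 1 `O=c1cc(CNCc2cccc(I)c2)oc2ccc(O)c(O)c12` gives > 100000 nM in an ADME assay on Huh-7 cells (Homo sapiens) for cytotoxicity (on this read-out higher numbers stand for lower toxicity in this test and lower numbers for higher toxicity in this test), a limit of the assay rather than a number. Compound 2 `O=c1cc(CNCc2cccc([N+](=O)[O-])c2)oc2ccc(O)c(O)c12` gives > 100000 nM in this assay, again only a limit. Among the measured compounds shown here, the step that the two limits leave unreadable from compound 1 to compound 2 therefore cannot be read, and the only evidence available is the limit of > 100000 nM in this assay, at which 2 of the 2 values shown sit. Compound 3 `Cc1ccc(CNCc2cc(=O)c3c(O)c(O)ccc3o2)cc1` differs from compound 1 by 4-methylphenyl in place of 3-iodophenyl on a saturated chain carbon bound to an amine nitrogen. With both measured neighbours sitting at the limit, no step beyond the scatter is expected in this assay. The expected step is a step that the limit leaves unreadable from compound 1 to compound 3, within the scatter. Compound 3 is estimated at about 150000 nM, between 60000 nM and 400000 nM, most probably reported again as a limit.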

Compound 3, half-maximal cytotoxic concentration: > 100000 nM
Compound 3 ended at the assay's limit; the forecaster's own chance of this, stated with the estimate: 80%; the middle value does not contradict the limit.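

No step can be read from compound 1 to compound 3, because both stand at a limit in this assay: the limit of > 100000 nM in this assay, at which 3 of the 3 values shown sit.

The compounds shown leave open whether compound 1, compound 2 and compound 3 differ at all in this assay.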